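Hydroxyphenyl placement on the shared core and cytotoxicity

The source may hold more compounds than are shown below. What is called first, only, known or untested is meant among the compounds shown, and "the series" means these compounds.

Two members of the series carry measurements so far. Compound 1 `Oc1ccc(-c2cc(-c3ccccc3O)cc(-c3cccc(O)c3)n2)cc1` and compound 2 `Oc1ccc(-c2cc(-c3ccccc3O)cc(-c3ccccc3O)n2)cc1` share the same core and differ only in one hydroxyphenyl group. In an ADME assay on HEK293 cells (Homo sapiens) for cytotoxicity, read by CCK-8 assay, with a stated time of 4 days (a higher number here means a weaker inhibitor, a lower number a stronger inhibitor), compound 1 gives 5650 nM, and in this assay compound 2 gives 6990 nM. The step of a 1.2-fold higher number from compound 1 to compound 2 (0.09 log units; within the scatter) shows that moving the hydroxyl from the 3-hydroxyphenyl to the 2-hydroxyphenyl position left the number essentially unchanged. Compound 2 therefore stands within the scatter of compound 1, and no ordering between the two can be claimed.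

Compound 3 `Oc1ccc(-c2cc(-c3ccccc3O)cc(-c3ccc(O)cc3)n2)cc1` is not yet measured. Relative to compound 2 the change is 4-hydroxyphenyl in place of 2-hydroxyphenyl on an aromatic carbon. Within the data shown here, the only measured step that bears on this change is a 1.2-fold higher number from compound 1 to compound 2 (0.09 log units; within the scatter), which also rearranged a hydroxyl on one of the three hydroxyphenyl groups and did not move the number beyond the scatter. On that basis no step beyond the scatter is expected in this assay, in either direction, for compound 3, and the expected step is a 1.1-fold lower number from compound 2 to compound 3 (0.03 log units; within the scatter). Compound 3 is estimated at 6500 nM, with a range from 3000 nM to 14000 nM.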

Compound 3, half-maximal inhibitory concentration: 780 nM
Compound 3: the middle estimate sits 8.3-fold (0.92 log units) above what was measured; the whole stated range lies above it.
By their numbers in this assay, from the lowest: compound 3; then compounds 1 and 2 (each within the scatter of the next).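

At this place, on an aromatic carbon next to the ring nitrogen, the hydroxyl arrangement on the phenyl group does matter in this assay: the 4-hydroxyphenyl group gives a 9.0-fold lower number from compound 2 to compound 3 (0.95 log units; beyond the scatter) and a 7.2-fold lower number from compound 1 to compound 3 (0.86 log units; beyond the scatter), both beyond the scatter, whereas the 2-hydroxyphenyl and 3-hydroxyphenyl groups remain within the scatter of each other, with a 1.2-fold higher number from compound 1 to compound 2 (0.09 log units; within the scatter). Among these three compounds, only the 4-hydroxyphenyl group separates from the others, and it does so with the same atoms joined differently and with the same counts of heavy atoms, hydrogen-bond donors and acceptors, and no net charge on either group. No measurement at hand accounts for this step.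

The compounds shown leave open whether the step needs the hydroxyl itself or would persist with a 4-methoxyphenyl, 4-aminophenyl or 4-fluorophenyl group in place of the 4-hydroxyphenyl group. Also open, as far as these compounds go, is how much the 2-hydroxyphenyl group and the other 4-hydroxyphenyl group, both shared by compound 3 with other members, contribute to its value.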